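Removing the tetrazolyl amide from compound 3

The source may report more compounds than this note shows. Statements on the series, on what has been measured and on what is new or still open speak of the compounds shown alone.

compound 1 `O=C(Cl)c1ccc2occc(=O)c2c1` gives "nd(insoluble)" (no result reported)
compound 2 `N#Cc1ccc2occc(=O)c2c1` gives "nd(insoluble)" (no result reported)
compound 3 `O=C(Nc1nnn[nH]1)c1ccc2occc(=O)c2c1` gives 0.7 ug/mL

Of the compounds shown here, three sharing one core have been tested so far, but only one produced a usable result. Within the data shown here, in a functional assay on cells (Mast cell, Rattus norvegicus) for inhibition, with a stated time of 15 min (on this read-out higher numbers stand for an effect only at larger amounts of compound and lower numbers for an effect already at smaller amounts), compound 3 gives 0.7 ug/mL and is the only one with a number. Among the measured compounds shown here, compound 1 and compound 2 have entries with no result, so they cannot be ranked against it, and no step between measured compounds is available as a guide.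

The next compound to be tested is compound 4 `O=C(O)c1ccc2occc(=O)c2c1`. It differs from compound 3 by one change: hydroxy in place of (1H-tetrazol-5-yl)amino on a carbonyl carbon. In words, this puts hydroxy in place of (1H-tetrazol-5-yl)amino on a carbonyl carbon.

Any forecast rests on a single anchor, compound 3 at 0.7 ug/mL, and that compound is also the only one of the three carrying the group that leaves. The expectation is therefore a loss of effect, which in this assay means a higher number. The estimated change is a 29-fold higher number from compound 3 to compound 4 (1.46 log units; beyond the scatter) and it is expected to lie beyond the usual scatter. The uncertainty is wide, and an entry without a number is also possible. For compound 4 the estimate is 20 ug/mL, with an expected range from 2 ug/mL to 200 ug/mL.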

Compound 4, concentration for half-maximal effect: > 18 ug/mL
Compound 4 ended at the assay's limit (the forecaster's own chance of this, stated with the estimate: 40%); the middle value is on the limit's open side.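

In this assay, among these compounds, hydroxy in place of (1H-tetrazol-5-yl)amino on a carbonyl carbon produces an at least 25-fold higher number from compound 3 to compound 4 (1.41 log units; beyond the scatter) and so provides the first readable comparison at this place on the shared core. Compound 4 gives > 18 ug/mL as a limit of the assay and not as a number. The step shows that the effect seen with compound 3 depends strongly on what is attached to this carbonyl carbon, although its full size stays unknown, and it rests on this single limit: the limit of > 18 ug/mL in this assay, at which 1 of the 4 values shown sits.

The change removes the tetrazole ring and the linking amide nitrogen together, so the compounds shown cannot tell whether the ring, the nitrogen or both account for the difference, and compound 1 and compound 2 give no number that could help. A simple amide carrying a phenyl group, or a triazole ring in place of the tetrazole on the same amide nitrogen, would be the kind of group needed to separate these parts.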